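Working notes on the aryl-amino variation of this series

The source may report more compounds than this note shows. Statements on the series, on what has been measured and on what is new or still open speak of the compounds shown alone.

Measured so far:
Compound 1 `FC(F)(F)c1ccc(CSc2nc(Nc3ccccc3C(F)(F)F)c3ccccc3n2)cc1` gives > 50000 nM in a functional assay on MCF7 cells (Homo sapiens) for cytotoxicity, read by MTT assay, with a stated time of 72 h (a lower number here means a stronger inhibitor, a higher number a weaker inhibitor), a limit of the assay.
Compound 2 `CCOc1ccccc1Nc1nc(SCc2ccc(C(F)(F)F)cc2)nc2ccccc12` gives > 50000 nM in this assay, again a limit.
Compound 3 `Cc1ccccc1Nc1nc(SCc2ccc(C(F)(F)F)cc2)nc2ccccc12` gives 37500 nM in this assay.

Among the measured compounds shown here, compound 3 holds the only number here; the two other values sit at the limit, see (the limit of > 50000 nM in this assay, at which 2 of the 3 values shown sit). The steps of an at least 1.3-fold lower number from compound 1 to compound 3 (0.12 log units; that floor lies within the scatter) and an at least 1.3-fold lower number from compound 2 to compound 3 (0.12 log units; that floor lies within the scatter) read as floors only, and a step that the two limits leave unreadable from compound 1 to compound 2 cannot be read at all. Compound 4 `Fc1ccc(Nc2nc(SCc3ccc(C(F)(F)F)cc3)nc3ccccc23)cc1` is not yet measured; it differs from compound 3 by 4-fluorophenyl in place of 2-methylphenyl on a nitrogen on an aromatic ring. For the measured compounds named here, no measured step covers this change. Compound 4 is expected near 40000 nM, between 15000 nM and 100000 nM. For compound 4 the expected step is a 1.1-fold higher number from compound 3 to compound 4 (0.03 log units; within the scatter), with a fair chance that only a limit is reported.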

Compound 4, half-maximal inhibitory concentration: 36300 nM
For compound 4 the middle estimate is 1.1-fold (0.04 log units) above the measured one, and the stated range covers the measured number.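

Exchanging 2-methylphenyl for 4-fluorophenyl on the nitrogen gives a 1.0-fold lower number from compound 3 to compound 4 (0.01 log units; within the scatter), so this change shows no readable difference in this assay, and the series now has a second true number. Against the two limit compounds only floors can be read: an at least 1.3-fold lower number from compound 2 to compound 4 (0.13 log units; that floor lies within the scatter), and an at least 1.3-fold lower number from compound 1 to compound 4 (0.13 log units; that floor lies within the scatter). These floors rest on a limit of the assay, not on numbers: the limit of > 50000 nM in this assay, at which 2 of the 4 values shown sit.

On these data alone, whether any aryl group here can give a step beyond the scatter remains open. So does what a carboxylic acid or an amine on this phenyl ring would do.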